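Swapping a Small Ring Amine for Dimethylamino

The compounds below may be only part of what the source reports. "The series", "measured", "known", "first", "only" and "open" are said of these compounds alone.

Of the compounds shown here, three have been tested in a functional assay on cells (Lymphocyte, Homo sapiens), read by trypan blue exclusion, with a stated time of 16 h, tested at 0.1 uM; a higher number here means a stronger effect of the compound at the concentration tested, a lower number a weaker effect. Compound 1 `CCCCCCCCCCc1c(C)c(N(C)C)nc(C)c1O` gives 34%, compound 2 `CCCCCCCCCCCCCCCCc1nc(N2CCC2)c(C)c(C)c1O` gives 54%, and compound 3 `CCCCCCCCCCCCCCCCc1c(C)c(N2CCC2)nc(C)c1O` gives 58%. Compound 2 stands second highest of these three numbers; its nearest neighbour is compound 3, whose number lies within the usual scatter of this kind of measurement, while compound 1 sits furthest away, with a number that falls beyond the scatter. Going by the values given here, no two of the measured compounds differ in only one place, so no single structural step can be read directly from the numbers so far.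

Compound 4 `CCCCCCCCCCCCCCCCc1nc(N(C)C)c(C)c(C)c1O` has not yet been measured. It differs from compound 2 in one place, described as dimethylamino in place of azetidin-1-yl on an aromatic carbon. Among the compounds with values here, the only other compound that carries a dimethylamino group is compound 1, but it also has a shorter chain than compound 2 and the groups sit in a different arrangement, so it cannot isolate the effect of the amine alone. The step from compound 2 to compound 4 in this assay is therefore expected to be small, if anything a slight decrease, and most likely within the scatter, at about a number 6 percentage points lower from compound 2 to compound 4 (within the scatter). Compound 4 is estimated to give 48%, in the range from 30% to 65%.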

Compound 4, a percentage reported as activity, at one concentration (the size of the read-out at that concentration, not a potency): 80%
The estimate for compound 4 lay 32 percentage points below the measured number, and the stated range ends below it.
By their numbers in this assay, from the lowest: compound 1; then compounds 2 and 3 (each within the scatter of the next); then compound 4.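

In this assay, going by these compounds alone, the change of dimethylamino in place of azetidin-1-yl on the aromatic carbon next to the ring nitrogen gives the first single-place comparison in this set, and it amounts to a number 26 percentage points higher from compound 2 to compound 4 (beyond the scatter). This shows that the effect at this concentration depends on which small amine sits at this position, even though the two groups match in hydrogen-bond donors, hydrogen-bond acceptors and net charge and differ in their heavy atoms and in having a ring or no ring. Nothing measured here explains why the open amine gives the higher number.

As far as these compounds go, it remains open whether the same swap would give a similar step in the arrangement of compound 3, or with the shorter chain of compound 1, since a single pair cannot show how far this result carries to another core arrangement or chain. Also open, from the compounds shown here alone, is how other amines at this same place, such as diethylamino or pyrrolidin-1-yl, would compare with dimethylamino and azetidin-1-yl.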